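Methoxy in Place of Chloro on the Aryl Ketone

The source may report more compounds than this note shows. Statements on the series, on what has been measured and on what is new or still open speak of the compounds shown alone.

Compound 3 `COc1cc(-c2cc(/C=C/C(=O)c3ccc(Cl)cc3)[nH]n2)cc(OC)c1OC` gives 11600 nM in a functional assay on MCF7 cells (Homo sapiens) for inhibition, read by MTT assay, with a stated time of 48 h (on this read-out lower numbers stand for stronger inhibition and higher numbers for weaker inhibition), the highest of the three numbers measured. Compound 2 `COc1cc(-c2cc(/C=C3\CCc4ccccc4C3=O)[nH]n2)cc(OC)c1OC` gives 8500 nM, within the scatter of compound 3, while compound 1 `COc1cc(-c2cc(/C=C/C(=O)c3ccc(N)cc3)[nH]n2)cc(OC)c1OC` gives 1600 nM. Among the measured compounds shown here, the one single-point step measured is a 7.3-fold higher number from compound 1 to compound 3 (0.86 log units; beyond the scatter), a modest move beyond the scatter. Compound 4 `COc1ccc(C(=O)/C=C/c2cc(-c3cc(OC)c(OC)c(OC)c3)n[nH]2)cc1` differs from compound 3 by methoxy in place of chloro on an aromatic carbon. For the measured compounds named here, no measured pair shows methoxy in place of chloro, so the guidance is indirect; because a 7.3-fold higher number from compound 1 to compound 3 (0.86 log units; beyond the scatter) is the only step on this aromatic carbon and concerns amino rather than methoxy, compound 4 is expected to shift less far in the same direction, a 2.3-fold lower number from compound 3 to compound 4 (0.37 log units; beyond the scatter). Compound 4 is therefore estimated at 5000 nM, with a range of 1500 nM to 16000 nM.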

Compound 4, half-maximal inhibitory concentration: 810 nM
Compound 4: the middle estimate sits 6.2-fold (0.79 log units) above what was measured; measured number outside the range, below it.
By their numbers in this assay, from the lowest: compounds 4 and 1 (each within the scatter of the next); then compounds 2 and 3 (each within the scatter of the next).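

In this assay, among the compounds shown here, the change from 4-chlorophenyl to 4-methoxyphenyl gives a 14-fold lower number from compound 3 to compound 4 (1.16 log units; beyond the scatter) and so shows that amino is not the only group at this aromatic carbon that stands clear of chloro. Methoxy and amino cannot be told apart here, with a 2.0-fold lower number from compound 1 to compound 4 (0.30 log units; within the scatter) lying within the scatter. No measurement shown here accounts for the step.

From the compounds shown here alone, whether hydroxy, ethoxy or dimethylamino at this carbon would stay with compound 4 and compound 1 or sit with compound 3 remains open. So does whether a fluoro group would differ from chloro at all.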